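A few compounds are considered here, and "the series" means these few. Any claim that something is new, unique, unknown or untested is made for them only; others in the source may bear on it.

Compound 1 `COc1ccc(/C=C/C(=O)/C=C/c2ccc(OCc3cn(CCOc4cc(=O)oc5ccccc45)nn3)c(OC)c2)cc1OC` is the reference point of the series: in a functional assay on PC-3 cells (Homo sapiens) for inhibition, read by sulforhodamine B assay, with a stated time of 48 h, tested at 50 uM (on this read-out lower numbers stand for less inhibition of growth and higher numbers for more inhibition of growth at the one concentration tested), compound 1 gives 19%. Compound 2 `COc1cc(/C=C/C(=O)/C=C/c2cccc3ccccc23)ccc1OCc1cn(CCCCOc2cc(=O)oc3ccccc23)nn1` in this assay gives "not active" (no number reported); for compound 2 no single number stands, so it cannot be placed on the same scale as compound 1 and serves only as a qualitative anchor. Compound 3 `COc1ccc(/C=C/C(=O)/C=C/c2ccc(OCc3cn(CCCCOc4cc(=O)oc5ccccc45)nn3)c(OC)c2)cc1OC` is the unmeasured member. The difference from compound 2 to compound 3 is 3,4-dimethoxyphenyl in place of naphthalen-1-yl on a double-bonded chain carbon bound to a double-bonded chain carbon. Compound 3 thereby carries the same 3,4-dimethoxyphenyl on the chain as compound 1 and differs from compound 1 only in the chain that links the two ends of the molecule. Among the compounds with values here, no step between measured compounds is known. In this assay the expectation for compound 3 is a small, measurable inhibition rather than none, near the level of compound 1 because compound 1 gives 19%; any step from compound 2 is expected to be small and upward, not clearly beyond the scatter. Compound 3 is estimated in this assay at 17%, with a range from 5% to 30%.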

Compound 3, percent growth inhibition at one concentration: "not active" (no number reported)
No number was reported for compound 3; there is nothing to compare the estimate with.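

In this assay compound 2 gives "not active" (no number reported) and compound 3 gives "not active" (no number reported), so no step can be read between them. No evidence bears on this result. The compounds shown leave open whether the linking chain or the naphthalen-1-yl to 3,4-dimethoxyphenyl change affects growth inhibition.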